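Expected effect of a 2-nitrophenyl swap on compound 3

A few compounds are considered here, and "the series" means these few. Any claim that something is new, unique, unknown or untested is made for them only; others in the source may bear on it.

- Compound 1 `O=C(/C=C/c1ccc([N+](=O)[O-])cc1)Nc1cc2c(Nc3ccc(F)c(Cl)c3)ncnc2cc1O[C@H]1CCOC1` gives 26700 nM
- Compound 2 `O=C(/C=C/c1cccc(Cl)c1Cl)Nc1cc2c(Nc3ccc(F)c(Cl)c3)ncnc2cc1O[C@H]1CCOC1` gives 30100 nM
- Compound 3 `COc1ccc(OC)c(/C=C/C(=O)Nc2cc3c(Nc4ccc(F)c(Cl)c4)ncnc3cc2O[C@H]2CCOC2)c1` gives 36300 nM

These three values come from a functional assay on MCF7 cells (Homo sapiens) for cytotoxicity, read by MTT assay, with a stated time of 72 h (on this read-out higher numbers stand for weaker inhibition and lower numbers for stronger inhibition), and the compounds differ only in the ring group at the end of the chain. Compound 3 stands within the usual scatter of both others, so the three cannot be ranked. Among the compounds with values here, the next compound to be tested is compound 4 `O=C(/C=C/c1ccccc1[N+](=O)[O-])Nc1cc2c(Nc3ccc(F)c(Cl)c3)ncnc2cc1O[C@H]1CCOC1`, and its one structural change is 2-nitrophenyl in place of 2,5-dimethoxyphenyl on a double-bonded chain carbon bound to a double-bonded chain carbon.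

Within the data shown here, three measured steps bear on this change. The closest is a 1.4-fold higher number from compound 1 to compound 3 (0.13 log units; within the scatter), since it exchanges a 4-nitrophenyl group for the same 2,5-dimethoxyphenyl group. The other two are a 1.1-fold higher number from compound 1 to compound 2 (0.05 log units; within the scatter) and a 1.2-fold higher number from compound 2 to compound 3 (0.08 log units; within the scatter), and all three steps lie within the scatter. These ring groups differ considerably, yet the number has barely moved. Among the measured compounds shown here, still, three compounds are a small base, and no measured compound carries a 2-nitrophenyl group. No step beyond the scatter is therefore expected in this assay, and the estimated step is a 1.2-fold lower number from compound 3 to compound 4 (0.08 log units; within the scatter).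

The estimate for compound 4 is 30000 nM, with an expected range from 17000 nM to 52000 nM.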

Compound 4, half-maximal inhibitory concentration: 28400 nM
Compound 4: middle estimate off by 1.1-fold (0.02 log units), on the high side, and the stated range covers the measured number.
By their numbers in this assay, from the lowest: compounds 1, 4, 2 and 3 (each within the scatter of the next).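

Placing 2-nitrophenyl where 4-nitrophenyl stood gives the first comparison of one substituent at two different ring positions on this chain, and in this assay the result is a 1.1-fold higher number from compound 1 to compound 4 (0.03 log units; within the scatter). Compared with the other two ring groups, the same 2-nitrophenyl group gives a 1.3-fold lower number from compound 3 to compound 4 (0.11 log units; within the scatter) and a 1.1-fold lower number from compound 2 to compound 4 (0.03 log units; within the scatter), so all four compounds now lie within the scatter of one another and cannot be ranked, even though the nitro, chloro and methoxy groups are very different substituents. Nothing available here explains why these ring groups read alike.

Going by these compounds, all four compounds carry a substituted phenyl ring on the double-bonded chain carbon, so it remains open whether replacing that ring with a dimethylamino group, or adding a carboxylic acid to it, would produce a step beyond the scatter. These values also come from a single cell line and one read-out, with the numbers all falling in a narrow band, so they cannot show whether these ring groups would also read alike in another test.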